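Urea aryl swap on the pyridinyl-pyrazole series: compound 3

This account rests on a few compounds, and the source may have more. Where it says the series, first, only, none or still open, it means among the compounds named here.

Two compounds of the shared core have numbers in a functional assay on NCI-H23 cells (Homo sapiens) for inhibition, read by sulforhodamine B assay, with a stated time of 48 h, tested at 10 uM; on this read-out higher numbers stand for a weaker effect at the one concentration tested and lower numbers for a stronger effect. Compound 1 `COc1cc(Cl)cc(-c2nn(-c3cccc(NC(=O)Nc4cccc(C(F)(F)F)c4)c3)cc2-c2ccncc2)c1` gives -5.1% in this assay, the highest of the two numbers shown. Compound 2 `O=C(Nc1cccc(-n2cc(-c3ccncc3)c(-c3cc(O)cc(Cl)c3)n2)c1)Nc1ccc(Cl)c(Cl)c1` gives -20.5% in this assay, and the gap to compound 1 lies beyond the scatter; compound 2 differs from compound 1 in more than one place, so this gap is not tied to a single change.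

Compound 3 `COc1cc(Cl)cc(-c2nn(-c3cccc(NC(=O)Nc4ccc(Cl)c(Cl)c4)c3)cc2-c2ccncc2)c1` has not yet been measured in this assay. Relative to compound 1 the change is 3,4-dichlorophenyl in place of 3-(trifluoromethyl)phenyl on an amide-type nitrogen. The entering group on the amide-type nitrogen is the same group that compound 2 carries at that position, while the rest of compound 3 matches compound 1.

Among the compounds with values here, no single-change step is available to size this move. Given that compound 2 gives -20.5% with the same urea aryl group, a modest step downward, toward a stronger effect, is expected for compound 3, of size a number 6.9 percentage points lower from compound 1 to compound 3 (within the scatter), though it may stay within the scatter. The estimate for compound 3 in this assay is -12%, with a range from -30% to 8%.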

Compound 3, a percentage reported as activity, at one concentration (the size of the read-out at that concentration, not a potency): 5.72%
Compound 3: the middle estimate sits 17.7 percentage points below what was measured, and the stated range covers the measured number.
By their numbers in this assay, from the lowest: compound 2; then compound 1; then compound 3.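

In this assay, within the data shown here, the first single-change reading at the urea aryl position comes from 3,4-dichlorophenyl in place of 3-(trifluoromethyl)phenyl on the amide-type nitrogen, which gives a number 10.8 percentage points higher from compound 1 to compound 3 (beyond the scatter) and so points to a weaker effect with the dichloro group on this methoxy-bearing background. With 3,4-dichlorophenyl held constant, methyl in place of hydrogen on the oxygen on the aromatic ring gives a number 26.2 percentage points higher from compound 2 to compound 3 (beyond the scatter) and also points to a weaker effect, so 3,4-dichlorophenyl alone does not carry the stronger effect seen with compound 2, and the read-out also responds to the group on that oxygen. Nothing available explains either step.

As far as these compounds go, each step is read on one background only, so it remains open whether the order of the two urea aryl groups holds when the oxygen carries hydrogen rather than methyl. The compounds shown also leave open how the read-out responds to a longer chain such as ethyl on that oxygen, or to an amine in place of the oxygen group.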